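This account rests on a few compounds, and the source may have more. Where it says the series, first, only, none or still open, it means among the compounds named here.

Measured so far:
compound 1, `COC(=O)c1cc(-c2csc(N/N=C/c3cccs3)n2)ccc1OCc1ccccc1`, 96.3%
compound 2, `Fc1ccc(-c2csc(N/N=C/c3ccc(Cl)cc3Cl)n2)cc1`, 96%

Both measured compounds share the hydrazone-linked core shown beside their structures. In a functional assay, read by spectrophotometry, with a stated time of 15 min, tested at 100 ug/mL (on this read-out lower numbers stand for a weaker effect and higher numbers for a stronger effect at the one concentration tested), compound 1 gives 96.3%. In this assay compound 2 gives 96%. On the numbers shown, compound 2 stands level with compound 1: the two values lie within the usual scatter of one another, so no order between them can be read from this assay.

The next compound, compound 3, `Cc1ccc(-c2csc(N/N=C/c3ccc(Cl)cc3Cl)n2)cc1`, keeps the core and the dichlorinated arm of compound 2 and differs in one place: methyl in place of fluoro on an aromatic carbon. Going by the values given here, no step between measured compounds is known for this kind of change, and the two numbers at hand sit close to the top of the read-out. The step of a number 2 percentage points lower from compound 2 to compound 3 (within the scatter) is therefore expected to be none beyond the scatter, with the only room for movement lying downward from a near-complete read-out. Compound 3 is expected to give 94%, within the range 84% to 99%, in this assay.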

Compound 3, a percentage reported as inhibition, at one concentration (the size of the read-out at that concentration, not a potency): 95.1%
Compound 3: the middle estimate sits 1.1 percentage points below what was measured, and the stated range covers the measured number.
By their numbers in this assay, from the lowest: compounds 3, 2 and 1 (each within the scatter of the next).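

This pair gives the series its first reading of a single change. With the core and the dichlorinated arm held fixed, going from 4-fluorophenyl to 4-methylphenyl gives a number 0.9 percentage points lower from compound 2 to compound 3 (within the scatter) in this assay. At this position, on an aromatic carbon para to a large group, fluoro and methyl therefore cannot be told apart on this read-out, and no measurement here bears on a reason for that.

Going by these compounds, whether an amine, a carboxylic acid or a longer chain at this position would shift the number beyond the scatter remains open, as does whether any group placed here could bring it down from near the top of the read-out. Also open, on these data alone, is whether compound 2 and compound 3 would stay level at a lower concentration: a single-concentration read-out close to its ceiling gives the size of the effect at that one concentration and says nothing about potency.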